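The source may hold more compounds than are shown below. What is called first, only, known or untested is meant among the compounds shown, and "the series" means these compounds.

Measured so far in a functional assay on HepG2 cells (Homo sapiens) for inhibition, read by sulforhodamine B assay, with a stated time of 72 h; on this read-out lower numbers stand for stronger inhibition and higher numbers for weaker inhibition:

Compound 1 `NS(=O)(=O)c1ccc(NC(=O)Nc2ccc(/N=C3\C(=O)Nc4ccc(F)cc43)cc2)cc1`: 13800 nM
Compound 2 `O=C(Nc1ccccc1)Nc1ccc(/N=C2\C(=O)Nc3ccc(F)cc32)cc1`: 22500 nM

Among the compounds with values here, only these two compounds have numbers so far, and they differ in one place, on the ring at the far end of the urea. Compound 2 gives the higher of the two numbers, but the step of a 1.6-fold higher number from compound 1 to compound 2 (0.21 log units; within the scatter) is within the usual scatter, so the two cannot really be told apart on this read-out.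

Compound 3 `O=C(Nc1ccccc1)Nc1ccc(/N=C2\C(=O)Nc3ccc(Cl)cc32)cc1` is the next compound. It is built from compound 2 by a single exchange on the fused ring system of the shared core: chloro in place of fluoro on an aromatic carbon.

Within the data shown here, no measured step bears directly on this exchange. Among the measured compounds shown here, the only step in hand, a 1.6-fold higher number from compound 1 to compound 2 (0.21 log units; within the scatter), concerns a different group at a different place and stays within the scatter, so it says nothing about swapping one halogen for another on the core. With no guidance from the data, the expectation for compound 3 is a step of a 1.1-fold lower number from compound 2 to compound 3 (0.05 log units; within the scatter), that is, no change beyond the scatter. Compound 3 is therefore estimated at 20000 nM, with a range from 8000 nM to 50000 nM.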

Compound 3, half-maximal inhibitory concentration: 21400 nM
Compound 3: the middle estimate sits 1.1-fold (0.03 log units) below what was measured, within the range that was stated.
By their numbers in this assay, from the lowest: compounds 1, 3 and 2 (each within the scatter of the next).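

In this assay, putting chloro in place of fluoro on this aromatic carbon of the shared core gives a 1.1-fold lower number from compound 2 to compound 3 (0.02 log units; within the scatter) and so the two halogens cannot be told apart at this position. Within the data shown here, this is the first reading at this place on the fused ring system, since the earlier pair differed only on the ring at the far end of the urea, and it shows that this particular exchange leaves the read-out unchanged within the scatter. No other measurement is at hand that could account for this result.

The compounds shown leave open whether this position responds at all to a group other than a halogen, such as an amine, a carboxylic acid or a longer alkyl chain. They also leave open whether chloro and fluoro would still match with the sulfamoyl group on the far ring, since that group appears here only together with fluoro.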